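The compounds below may be only part of what the source reports. "The series", "measured", "known", "first", "only" and "open" are said of these compounds alone.

Compounds measured so far:

Compound 1: `CN(C)c1ccc(/C=C2/SC(N(c3ccccc3)c3ccccc3)=NC2=O)cc1`; in this assay compound 1 gives > 100000 nM, which is a limit of the assay and not a number.
Compound 2: `CN(C)c1ccc(/C=C2/SC(N(C)c3ccccc3)=NC2=O)cc1`; compound 2 gives > 100000 nM, again a limit rather than a number.

Going by the values given here, in an ADME assay on cells (Homo sapiens) for cytotoxicity, read by sulforhodamine B assay, with a stated time of 48 h (on this read-out higher numbers stand for an effect only at larger amounts of compound and lower numbers for an effect already at smaller amounts), the single step between measured compounds, a step that the two limits leave unreadable from compound 1 to compound 2, cannot be read, because of the limit of > 100000 nM in this assay, at which 2 of the 2 values shown sit. Among the compounds with values here, compound 2 therefore stands at the limit, and the one further value shown for comparison is a limit as well; nothing places compound 2 at a numbered position.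

Compound 3, `CN1CCN(c2ccc(/C=C3/SC(N(C)c4ccccc4)=NC3=O)cc2)CC1`, differs from compound 2 by 4-methylpiperazin-1-yl in place of dimethylamino on an aromatic carbon. No measured step bears on this change directly, and the only step shown, from compound 1 to compound 2, is itself unreadable. The expectation for compound 3 is therefore simply that it behaves as compound 2 does, and the step of a number no higher from compound 2 to compound 3 (the limit leaves the size open) is estimated as none beyond the scatter. Compound 3 is expected to give about 100000 nM, with a range from 30000 nM to 300000 nM.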

Compound 3, half-maximal effective concentration: > 100000 nM
Compound 3 ended at the assay's limit; the forecaster's own chance of this, stated with the estimate: 75%; the middle value sits exactly at the limit.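

The step between compound 2 and compound 3 cannot be read, because in this assay both stand at a limit and not at a number: the limit of > 100000 nM in this assay, at which 3 of the 3 values shown sit. The compounds shown leave open where compound 1, compound 2 and compound 3 would fall on a numbered scale, and whether 4-methylpiperazin-1-yl in place of dimethylamino changes the read-out at all.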